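Adding one methyl to compound 2

This account rests on a few compounds, and the source may have more. Where it says the series, first, only, none or still open, it means among the compounds named here.

In an ADME assay on BaF3 cells (Mus musculus) for antiproliferative activity, read by CCK-8 assay, with a stated time of 72 h (a lower number here means a stronger inhibitor of growth, a higher number a weaker inhibitor of growth), compound 1 `Cc1n[nH]c2cc(SCCC(=O)Nc3ccc(CN4CCN(C)CC4)c(C(F)(F)F)c3)ccc12` gives 3900 nM and compound 2 `CN1CCN(Cc2ccc(NC(=O)CCSc3ccc4c(-c5cccnc5)n[nH]c4c3)cc2C(F)(F)F)CC1` gives 2650 nM. These two numbers cannot be told apart, so compound 2 stands level with compound 1. Compound 3 `Cc1ccc(-c2n[nH]c3cc(SCCC(=O)Nc4ccc(CN5CCN(C)CC5)c(C(F)(F)F)c4)ccc23)cn1` has not yet been measured. It carries methyl in place of hydrogen on an aromatic carbon of compound 2, turning pyridin-3-yl into 6-methylpyridin-3-yl: methyl in place of hydrogen on an aromatic carbon. Among the compounds with values here, only one measured step bears on this, and only indirectly, as it concerns a different place on the shared core: a 1.5-fold lower number from compound 1 to compound 2 (0.17 log units; within the scatter). Even exchanging methyl for a whole ring there left the number within the scatter. No shift beyond the scatter is therefore expected in this assay, and the estimated step is a 1.1-fold higher number from compound 2 to compound 3 (0.02 log units; within the scatter). Compound 3 is estimated at 2800 nM, with an expected range of 1200 nM to 6500 nM.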

Compound 3, concentration for 50% growth inhibition: 1180 nM
Compound 3: middle estimate off by 2.4-fold (0.38 log units), on the high side, and the stated range ends above it.
By their numbers in this assay, from the lowest: compound 3; then compounds 2 and 1 (each within the scatter of the next).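

In this assay, adding methyl next to the ring nitrogen, which turns pyridin-3-yl into 6-methylpyridin-3-yl, gives a 2.2-fold lower number from compound 2 to compound 3 (0.35 log units; beyond the scatter). This is a modest step, but it lies beyond the scatter, whereas exchanging methyl on the shared core for unsubstituted pyridin-3-yl stayed within it. With the methyl in place, the same exchange on the core gives a 3.3-fold lower number from compound 1 to compound 3 (0.52 log units; beyond the scatter), although nothing measured here accounts for what the added methyl does.

Going by these compounds, it remains open whether a different group on this carbon, such as ethyl, methoxy, chlorine or an amine, would match or exceed methyl, or whether methyl on another carbon of this ring would have the same effect. On these data alone, the gain also rests on a single pair, so whether it carries over to other changes elsewhere on the shared core is unknown.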